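This account rests on a few compounds, and the source may have more. Where it says the series, first, only, none or still open, it means among the compounds named here.

Of the compounds shown here, two sharing a common core have been measured in an assay on CHO cells for displacement of a labelled ligand from histamine receptor H3 (Macaca mulatta), read by scintillation counting, with a stated time of 1 h; a higher number here means a weaker inhibitor, a lower number a stronger inhibitor. Compound 1 `CC1CCCN1C1CCN(c2ccc(NC(=O)Nc3cc(Cl)cc(Cl)c3)cc2)C1` gives 19.1 nM. Compound 2 `CC1CCCN1C1CCN(c2ccc(NC(=O)NC3CCCCC3)cc2)C1` gives 4.1 nM. For the measured compounds named here, the single measured step, a 4.7-fold lower number from compound 1 to compound 2 (0.67 log units; beyond the scatter), concerns the group on the amide-type nitrogen, where cyclohexyl replaced 3,5-dichlorophenyl. Going by the values given here, on these two numbers compound 2 stands lowest, with compound 1 its only neighbour.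

Compound 3 `Cc1cc(N2CCC(N3CCCC3C)C2)ccc1NC(=O)NC1CCCCC1` has not yet been measured. It differs from compound 2 by methyl in place of hydrogen on an aromatic carbon. Among the compounds with values here, no measured step bears on this change: the only measured step altered the substituent on the amide-type nitrogen and says nothing about the six-membered aromatic ring of carbon only. With no guide from the data, the expected step of a 1.2-fold higher number from compound 2 to compound 3 (0.09 log units; within the scatter) is none beyond the scatter. Compound 3 is therefore estimated at 5 nM, with a range from 2 nM to 15 nM.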

Compound 3, inhibition constant: 4.6 nM
Compound 3: middle estimate off by 1.1-fold (0.04 log units), on the high side; measured number inside the range.
By their numbers in this assay, from the lowest: compounds 2 and 3 (each within the scatter of the next); then compound 1.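

In this assay, methyl in place of hydrogen on an aromatic carbon, ortho to a large group and meta to a large group, gave a 1.1-fold higher number from compound 2 to compound 3 (0.05 log units; within the scatter), so adding this one carbon at this position produced no difference beyond the scatter. For the compounds shown here, the earlier step had concerned only the group on the amide-type nitrogen, whereas this is the first reading on the six-membered aromatic ring, and it holds only for methyl with cyclohexyl on that nitrogen. Nothing available explains this result.

On these data alone, it remains open whether a methoxy group, a chlorine atom or an amine at the same place would read like methyl. Also open, as far as these compounds go, is whether methyl would read the same with 3,5-dichlorophenyl in place of cyclohexyl on the amide-type nitrogen.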